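A few compounds are considered here, and "the series" means these few. Any claim that something is new, unique, unknown or untested is made for them only; others in the source may bear on it.

In a functional assay on HCT-116 cells (Homo sapiens) for antiproliferative activity, read by sulforhodamine B assay, with a stated time of 72 h (a lower number here means a stronger inhibitor, a higher number a weaker inhibitor), three compounds on the shared core have numbers. Compound 1 `Cn1ncc(Cl)c1-c1cc(C(=O)N[C@@H]2CNCC[C@H]2c2ccc(C(F)(F)F)cc2)oc1Cl` gives 280 nM. Compound 2 `Cn1ncc(Cl)c1-c1cc(C(=O)N[C@@H]2CN[C@H](CCN3CCCCC3)C[C@H]2c2ccc(Cl)c(Cl)c2)oc1Cl` gives 1020 nM and compound 3 `CNC(=O)C[C@@H]1C[C@@H](c2ccc(F)c(F)c2)[C@H](NC(=O)c2cc(-c3c(Cl)cnn3C)c(Cl)o2)CN1` gives 1100 nM, two values within the scatter of each other. Compound 2 stands beyond the scatter above compound 1.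

Compound 4 `CCC[C@@H]1C[C@@H](c2ccc(Cl)c(Cl)c2)[C@H](NC(=O)c2cc(-c3c(Cl)cnn3C)c(Cl)o2)CN1` has no number yet. It departs from compound 2 by methyl in place of piperidin-1-yl on a saturated chain carbon, two bonds along the chain from a saturated ring carbon, turning the 2-(piperidin-1-yl)ethyl chain into propyl. Within the data shown here, no measured pair isolates this change. Among the measured compounds shown here, the only hint is that compound 1, which has no such chain but also differs elsewhere, gives 280 nM.

The step expected in this assay is a 1.7-fold lower number from compound 2 to compound 4 (0.23 log units; within the scatter), a slight lean towards a lower number that stays within the scatter. Compound 4 is estimated at 600 nM, with an expected range from 200 nM to 1800 nM.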

Compound 4, half-maximal inhibitory concentration: 1020 nM
Compound 4: the middle estimate sits 1.7-fold (0.23 log units) below what was measured; the measured number falls inside the stated range.
By their numbers in this assay, from the lowest: compound 1; then compounds 2, 4 and 3 (each within the scatter of the next).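

In this assay, replacing piperidin-1-yl with methyl on a saturated chain carbon, two bonds along the chain from a saturated ring carbon, gives no change at the digits printed from compound 2 to compound 4 (within the scatter). At this position, the number therefore does not depend on the ring or its nitrogen, and the 2-(piperidin-1-yl)ethyl and propyl chains cannot be told apart. No supporting measurement explains this flat result.

Still open, going by these compounds, is whether a carboxylic acid or a primary amine at the chain end would move the number. A longer alkyl chain is equally untested by the compounds shown.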